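The compounds below may be only part of what the source reports. "The series", "measured", "known", "first", "only" and "open" are said of these compounds alone.

Measured compounds:
compound 1, `CC(=O)SCCC(CCCCC(=O)Nc1ccccc1)SC(C)=O`, 15.4%
compound 2, `CC(=O)SCCC(CCCCC(=O)Nc1ccc(Cl)cc1)SC(C)=O`, 9.89%
compound 3, `O=C(CCCCC(CCSC(=O)c1ccccc1)SC(=O)c1ccccc1)Nc1ccccc1`, 0.6%

In a functional assay on NCI-H460 cells (Homo sapiens) for inhibition, read by MTT assay, with a stated time of 24 h, tested at 0.1 ug/mL (a lower number here means less inhibition of growth, a higher number more inhibition of growth at the concentration tested), compound 1 gives 15.4%, and compound 2, which carries chloro in place of hydrogen on an aromatic carbon, gives 9.89%; the step of a number 5.5 percentage points lower from compound 1 to compound 2 (within the scatter) is within the scatter. Compound 3 gives 0.6%; how its core differs from that of compound 1 is not broken down here. Compound 4, `O=C(CCCCC(CCSC(=O)c1ccccc1)SC(=O)c1ccccc1)Nc1ccccc1Cl`, has not yet been measured in this assay. It carries chloro in place of hydrogen on an aromatic carbon; this is the same kind of change as from compound 1 to compound 2, but the place differs: para to a large group in compound 2, ortho to a large group in compound 4. Because the step of a number 5.5 percentage points lower from compound 1 to compound 2 (within the scatter) stayed within the scatter, a similarly small step a number 1.4 percentage points higher from compound 3 to compound 4 (within the scatter) is expected here. For compound 4 the estimated value in this assay is 2%, between -8% and 12%.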

Compound 4, percent growth inhibition at one concentration: 15.1%
Beside the measured number, compound 4's estimate is 13.1 percentage points below it; the measured number lies above the stated range.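

In this assay the effect of chloro in place of hydrogen on an aromatic carbon did not carry over from one core to the other: the same change on two cores in this assay, a number 5.5 percentage points lower (within the scatter) from compound 1 to compound 2 and a number 14.5 percentage points higher (beyond the scatter) from compound 3 to compound 4, 20 percentage points apart, beyond the scatter of two such steps. On the core of compound 3, the change gave a modest rise in growth inhibition at the concentration tested (a number 14.5 percentage points higher from compound 3 to compound 4 (beyond the scatter)). Among the compounds shown here, this does not show that the core alone sets the outcome, since the chloro group also sits in a different place in the two pairs, ortho to a large group in compound 4, and only two pairs are available.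

The compounds shown leave open how a 2-chlorophenyl group would behave on the core of compound 1. They also leave open whether a fluoro or methoxy group in that place would give a similar result.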